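The compounds below may be only part of what the source reports. "The series", "measured", "known", "first", "only" and "open" are said of these compounds alone.

Measured compounds:
Compound 1 `COc1ccc(-c2c(Br)c(=O)c3c(OC)cc(OC)cc3n2S(=O)(=O)c2ccc(OC)cc2)cc1` gives 49700 nM in an ADME assay on BJ cells (Homo sapiens) for antiproliferative activity, with a stated time of 72 h; a higher number here means that more compound is needed for the effect, a lower number that less compound is needed.
Compound 2 `COc1ccc(-c2cc(=O)c3c(OC)cc(OC)cc3n2S(=O)(=O)c2c(F)c(F)c(F)c(F)c2F)cc1` gives > 34400 nM in this assay.

Compound 1 is the only one of the two with a numerical reading in this assay, and that reading is high on the scale shown. Compound 2 is reported only as a limit in this assay; its value is not a number, and it sits at the limit of > 34400 nM in this assay, at which 1 of the 2 values shown sits. For the measured compounds named here, no step between measured compounds is available here, so nothing is known about how a change on the sulfonyl sulfur moves the read-out.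

Compound 3 `COc1ccc(-c2cc(=O)c3c(OC)cc(OC)cc3n2S(=O)(=O)c2ccc(OC)cc2)cc1` has not yet been measured in this assay. It differs from compound 2 in one place: 4-methoxyphenyl in place of 2,3,4,5,6-pentafluorophenyl on a sulfonyl sulfur. Since compound 2 stands at a limit, the size and direction of the change cannot be read from it; the account expects no step beyond the usual scatter, as a step that the limit leaves unreadable from compound 2 to compound 3. Compound 3 is therefore estimated at 40000 nM, with a range from 15000 nM to 100000 nM, and a fair chance that only a limit is reported.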

Compound 3, half-maximal effective concentration: > 82700 nM
Compound 3 ended at the assay's limit; the forecaster's own chance of this, stated with the estimate: 40%; middle value at least 2.0-fold (0.31 log units) away from the limit.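

With hydrogen in place of bromo on an aromatic carbon, this assay gives its first readable step, an at least 1.6-fold higher number from compound 1 to compound 3 (0.22 log units; that floor lies within the scatter), so taking away the bromo does not bring the number down, although the floor of this step does not clear the usual scatter. Compound 3 is reported only as a limit and not as a number: the limit of > 82700 nM in this assay, at which 1 of the 3 values shown sits. Compound 2 is also reported only as a limit, so the step for 4-methoxyphenyl in place of 2,3,4,5,6-pentafluorophenyl on a sulfonyl sulfur cannot be read, and neither group can be placed ahead of the other.

The compounds shown leave open whether any other group on the sulfonyl sulfur, such as a methyl or a 4-aminophenyl, would give a numerical reading in this assay when hydrogen stands on the aromatic carbon. They also leave open whether chloro or a nitrile in place of that hydrogen would read as a number, as the bromo of compound 1 does at 49700 nM, and how far such a group would move it.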